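Fluoro for trifluoromethyl: expected cytotoxicity on Vero cells

The source may hold more compounds than are shown below. What is called first, only, known or untested is meant among the compounds shown, and "the series" means these compounds.

The measured compounds and their values:
Compound 1 `O=[N+]([O-])c1cn2c(n1)OC[C@@H](OCc1cccc(-c3ccc(C(F)(F)F)cc3)c1)C2` gives in an ADME assay on Vero cells (Chlorocebus sabaeus) for cytotoxicity, with a stated time of 72 h; a higher number here means a weaker inhibitor, a lower number a stronger inhibitor > 128000 nM, which is a limit of the assay and not a number.
Compound 2 `N#Cc1ccc(-c2cccc(CO[C@@H]3COc4nc([N+](=O)[O-])cn4C3)c2)cc1` gives in this assay > 128000 nM, again a limit of the assay.
Compound 3 `O=[N+]([O-])c1cn2c(n1)OC[C@@H](OCc1ccc(-c3ccc(C(F)(F)F)cc3)s1)C2` gives in this assay > 128000 nM, also a limit of the assay.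

Compound 3 therefore stands where every measured value of this small set stands: at the limit of > 128000 nM in this assay, at which 3 of the 3 values shown sit. Within the data shown here, no compound here shows a readable number, so none can be called more or less toxic than another.

The new compound 4 `O=[N+]([O-])c1cn2c(n1)OC[C@@H](OCc1ccc(-c3ccc(F)cc3)s1)C2` differs from compound 3 in one place: fluoro in place of trifluoromethyl on an aromatic carbon. Among the measured compounds shown here, the only measured step that resembles it, an exchange of the same trifluoromethyl for a different small group, is a step that the two limits leave unreadable from compound 1 to compound 2, and its size cannot be read, since both ends sit at the limit.

With nothing beyond limits to build on, the step of a number no higher from compound 3 to compound 4 (the limit leaves the size open) is expected to remain unreadable, with no change beyond the scatter. Compound 4 is expected to give about 128000 nM in this assay, within a range from 40000 nM to 300000 nM, and the most likely outcome is that the assay again reports only a limit.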

Compound 4, half-maximal inhibitory concentration: > 128000 nM
Compound 4: no number, only a limit; the forecaster's own chance of this, stated with the estimate: 85%; the middle value lies on the limit itself.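

The exchange of trifluoromethyl for fluoro between compound 3 and compound 4 cannot be sized, because both compounds sit at an assay limit and not at a number: the limit of > 128000 nM in this assay, at which 4 of the 4 values shown sit.

The compounds shown leave open how far beyond that limit each one lies in this assay, and so whether these groups differ at all there.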